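A few compounds are considered here, and "the series" means these few. Any claim that something is new, unique, unknown or untested is made for them only; others in the source may bear on it.

Measured in an ADME assay on HepG2 cells (Homo sapiens) for cytotoxicity, read by MTT assay, with a stated time of 72 h; a lower number here means a stronger inhibitor, a higher number a weaker inhibitor:
- Compound 1 `Cc1ccc(S(=O)(=O)Cc2nc(Nc3ccccc3Cl)c3ccccc3n2)cc1`: > 50000 nM (a limit of the assay, not a number)
- Compound 2 `CC(C)=Cc1nc(Nc2ccccc2)c2cc([N+](=O)[O-])ccc2n1`: 50000 nM

Within the data shown here, compound 2, at 50000 nM, carries the only actual number in this assay. Compound 1 is known only through a limit, > 50000 nM.

The next compound to be tested is compound 3 `CC(C)=Cc1nc(Nc2cccc(C(F)(F)F)c2)c2cc([N+](=O)[O-])ccc2n1`. It departs from compound 2 by a single change, trifluoromethyl in place of hydrogen on an aromatic carbon, meta to a large group. Among the measured compounds shown here, no measured pair of compounds shows what such a change does in this assay, so the expectation rests on compound 2 alone. The expected step is small and leans slightly toward stronger inhibition, a 1.7-fold lower number from compound 2 to compound 3 (0.22 log units; within the scatter). Compound 3 is estimated at 30000 nM, with an expected range from 10000 nM to 60000 nM.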

Compound 3, half-maximal inhibitory concentration: > 100000 nM
Compound 3 ended at the assay's limit (the forecaster's own chance of this, stated with the estimate: 35%); middle value at least 3.3-fold (0.52 log units) from the limit.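

In this assay, among these compounds, trifluoromethyl in place of hydrogen on an aromatic carbon, meta to a large group, gives the first step that can be read for any change: an at least 2.0-fold higher number from compound 2 to compound 3 (0.30 log units; that floor lies within the scatter). The step gives no sign of stronger inhibition, although its floor does not clear the scatter. From the compounds shown here alone, its true size stays unknown because compound 3 stands at a limit of the assay and not at a number: the limit of > 100000 nM in this assay, at which 1 of the 3 values shown sits.

Going by these compounds, whether a methoxy group or an amine on the same aromatic carbon would give a number in this assay stays open, as does how far compound 3 lies past its limit. Compound 1 differs from compound 2 in more than one place, so it cannot show whether any single change matters here.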